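Cyclic amine exchange on a fused aromatic core

A few compounds are considered here, and "the series" means these few. Any claim that something is new, unique, unknown or untested is made for them only; others in the source may bear on it.

Compound 1 `Cn1cc(-c2ccc3nnc(Sc4ccc5ncc(N6CCC(N)C6)cc5c4)n3c2)cn1`: > 8.33 h
Compound 2 `Cn1cc(-c2ccc3nnc(Sc4ccc5ncc(NC6CCOC6)cc5c4)n3c2)cn1`: 0.05 h

As far as these compounds go, compound 1 carries 3-aminopyrrolidin-1-yl on the core; in an ADME assay on cytosol from liver for pharmacokinetics, with aldehyde oxidase 1 (Macaca fascicularis) as the target, read by LC-MS, with a stated time of 120 min, tested at 1 uM (a lower number here means that the compound disappears faster, a higher number that the compound lasts longer), compound 1 gives only a limit of the assay, > 8.33 h, so its true number is unknown (the limit of > 8.33 h in this assay, at which 1 of the 2 values shown sits). Compound 2 gives 0.05 h. Among the measured compounds shown here, the one measured step, an at least 160-fold lower number from compound 1 to compound 2 (2.22 log units; beyond the scatter), puts the two far apart. Compound 3 `Cn1cc(-c2ccc3nnc(Sc4ccc5ncc(NC6CCOCC6)cc5c4)n3c2)cn1` differs from compound 1 by (oxan-4-yl)amino in place of 3-aminopyrrolidin-1-yl on an aromatic carbon, a change of the same kind as that to compound 2. A step of similar size and direction, an at least 83-fold lower number from compound 1 to compound 3 (1.92 log units; beyond the scatter), is therefore expected. For compound 3 the estimated half-life in this assay is 0.1 h, within 0.02 h to 0.6 h.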

Compound 3, half-life: 4.52 h
The estimate for compound 3 lay 45-fold (1.66 log units) below the measured number; measured number outside the range, above it.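

In this assay, the exchange of the amine at this position does not by itself bring a collapse: oxan-4-yl in place of oxolan-3-yl on the nitrogen gives a 90-fold higher number from compound 2 to compound 3 (1.96 log units; beyond the scatter). The ring on that nitrogen therefore matters greatly here, while leaving 3-aminopyrrolidin-1-yl for (oxan-4-yl)amino gives only an at least 1.8-fold lower number from compound 1 to compound 3 (0.26 log units; that floor lies within the scatter). The value of compound 1 is only a limit of the assay: the limit of > 8.33 h in this assay, at which 1 of the 3 values shown sits.

As far as these compounds go, how far compound 3 truly lies from compound 1 stays unknown. From the compounds shown here alone, it also stays open whether a piperidin-4-ylamino group, or an open-chain 2-methoxyethylamino group, would follow compound 3 or compound 2.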